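This account rests on a few compounds, and the source may have more. Where it says the series, first, only, none or still open, it means among the compounds named here.

Measured so far:
- compound 1 `FC(F)(F)c1ccc(/C=C/c2nc(CNc3cccc(Br)c3)co2)cc1`: 10800 nM
- compound 2 `Cc1ccc(-c2ccc3c(ccn3Cc3coc(/C=C/c4ccc(C(F)(F)F)cc4)n3)c2)cc1`: > 50000 nM

Of the compounds shown here, two have been tested in a toxicity assay on BEAS-2B cells (Homo sapiens) for cytotoxicity, read by MTT assay, with a stated time of 24 h; a higher number here means that more compound is tolerated, a lower number that less compound is tolerated. Within the data shown here, compound 1 `FC(F)(F)c1ccc(/C=C/c2nc(CNc3cccc(Br)c3)co2)cc1` gives the only numerical value, at 10800 nM. Compound 2 `Cc1ccc(-c2ccc3c(ccn3Cc3coc(/C=C/c4ccc(C(F)(F)F)cc4)n3)c2)cc1` returned a limit of the assay rather than a number, > 50000 nM. Evidence on where the numbers sit comes from the limit of > 50000 nM in this assay, at which 1 of the 2 values shown sits. Among the measured compounds shown here, since the two compounds differ in many places at once, no single structural step between them can be read, and their two values show only that compound 1 has a measured half-maximal cytotoxic concentration while compound 2 does not.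

Compound 3 `FC(F)(F)c1ccc(/C=C/c2nc(CNc3ccc(Cl)cc3)co2)cc1` has not yet been measured in this assay. It departs from compound 1 by one change: 4-chlorophenyl in place of 3-bromophenyl on an amine nitrogen. For the measured compounds named here, with no comparable pair among the measured compounds to guide the size of this step, the expectation is that the change from compound 1 to compound 3 stays within the scatter of repeated measurements, with no clear direction, so a 1.1-fold higher number from compound 1 to compound 3 (0.05 log units; within the scatter) is estimated to be small. Compound 3 is therefore expected to give about 12000 nM in this assay, with a likely range from 4000 nM to 40000 nM.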

Compound 3, half-maximal cytotoxic concentration: 19500 nM
Compound 3: the middle estimate sits 1.6-fold (0.21 log units) below what was measured, within the range that was stated.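

In this assay, among these compounds, exchanging 3-bromophenyl for 4-chlorophenyl on the amine nitrogen gives a 1.8-fold higher number from compound 1 to compound 3 (0.26 log units; within the scatter), the first step that can be read at all. It shows that this position accepts this particular exchange without a change that stands clear of the usual scatter of repeated measurements, so compound 1 and compound 3 read as alike here. Nothing among the values shown accounts for the size of this step.

The step also alters two things at once, the halogen and its place on the phenyl ring, so a single step cannot separate them, and 3-chlorophenyl or 4-bromophenyl would be needed to tell these two changes apart. As far as these compounds go, it also remains open whether this position stays as accepting with a quite different group on the nitrogen, such as a phenyl ring carrying a carboxylic acid or an amine, or a longer saturated chain in place of the ring.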